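Methoxy in place of chloro: compound 3 to compound 4

The source may report more compounds than this note shows. Statements on the series, on what has been measured and on what is new or still open speak of the compounds shown alone.

Three compounds have been run in an ADME assay on CCRF-CEM cells (Homo sapiens) for cytotoxicity, with a stated time of 72 h; a higher number here means a weaker inhibitor, a lower number a stronger inhibitor. Compound 1 `Clc1ccc(Cc2nn3cc(-c4ccc(Br)cc4)nc3s2)cc1` returns only a limit, > 250000 nM, and no number. Compound 2 `O=c1oc2ccccc2cc1-c1cn2nc(Cc3ccc(Cl)cc3)sc2n1` likewise stops at a limit, > 10000 nM. Compound 3 `Clc1ccc(Cc2nn3c(Br)c(-c4ccc(Cl)cc4)nc3s2)cc1` also gives a limit, > 250000 nM. Compound 3 thus stands at the higher of the two limits seen: the limit of > 250000 nM in this assay, at which 2 of the 3 values shown sit, while (the limit of > 10000 nM in this assay, at which 1 of the 3 values shown sits). Among the measured compounds shown here, none of the three values is a number, so no step between measured compounds can be sized, and compound 3 cannot be ordered against the others beyond the statement that all three read as weak or inactive.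

Compound 4 `COc1ccc(-c2nc3sc(Cc4ccc(Cl)cc4)nn3c2Br)cc1` is compound 3 with one change: methoxy in place of chloro on an aromatic carbon. The group enters on an aromatic carbon of a six-membered aromatic ring of carbon only, para to a large group.

For the measured compounds named here, with no measured step anywhere in the set, the expectation rests on compound 3 alone, which gives > 250000 nM. No direction can be supported; the step is estimated as an at least 1.2-fold lower number from compound 3 to compound 4 (0.09 log units; that floor lies within the scatter), that is, nothing beyond the scatter. Compound 4 is expected at 200000 nM, within 20000 nM to 1000000 nM, and most likely to be reported again as a limit rather than a number.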

Compound 4, half-maximal inhibitory concentration: 58000 nM
Compound 4: middle estimate off by 3.4-fold (0.54 log units), on the high side; low and high end bracket the measured number.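

In this assay, the change from 4-chlorophenyl to 4-methoxyphenyl gives an at least 4.3-fold lower number from compound 3 to compound 4 (0.63 log units; beyond the scatter), so this position on the six-membered aromatic ring, para to a large group, does affect the read-out. From the compounds shown here alone, compound 3 reads only as a limit, so the step has a floor and no upper bound, and its true size remains unknown. Compound 4 is the only compound in the set with a number; the other three remain limits of the assay, and the most frequent is: the limit of > 250000 nM in this assay, at which 2 of the 4 values shown sit.

A single exchange cannot show whether the shift in this assay follows from gaining methoxy or from losing chloro, and no cause for it can be assigned from these data. Going by these compounds, whether the same position tolerates or rewards other groups remains open, for example a hydroxyl, an amine, a carboxylic acid or a longer alkoxy chain such as ethoxy, as does whether the bromine on the shared core matters once methoxy is in place.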